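The compounds below may be only part of what the source reports. "The series", "measured", "known", "first", "only" and "open" are said of these compounds alone.

Measured compounds in an ADME assay on HepG2 2.2.15 cells (Homo sapiens) for cytotoxicity; on this read-out lower numbers stand for higher toxicity in this test and higher numbers for lower toxicity in this test:
- compound 1, `O=c1c(CCO)c(-c2ccccc2Cl)c2cc(Cl)ccc2n1-c1ccccc1`: 26000 nM
- compound 2, `O=c1c(CCO)c(-c2ccccc2Cl)c2cc(Cl)ccc2n1-c1c(F)cccc1F`: a limit of the test, > 2300000 nM
- compound 3, `CCCCCCCC(=O)OCCc1c(-c2ccccc2Cl)c2cc(Cl)ccc2[nH]c1=O`: 78000 nM

Compound 3 holds the higher of the two numbers, with compound 1 lower by a gap beyond the scatter. Compound 2 sits at a limit of > 2300000 nM in this assay, at which 1 of the 3 values shown sits, rather than at a number. For the measured compounds named here, the only step measured between two compounds is an at least 88-fold higher number from compound 1 to compound 2 (1.94 log units; beyond the scatter), which changes the group on the aromatic nitrogen; it touches a part of the core that compound 3 and compound 4 do not share, so it gives no guide to the change at hand.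

Compound 4, `O=C(CCC1CCCCC1)OCCc1c(-c2ccccc2Cl)c2cc(Cl)ccc2[nH]c1=O`, differs from compound 3 in one place: cyclohexyl in place of pentyl on a saturated chain carbon, two bonds along the chain from a carbonyl carbon. Both the leaving and the entering groups are carbon only, with no donors or acceptors, so no shown step speaks for a change beyond the scatter in this assay.

Compound 4 is therefore expected to give about 80000 nM in this assay, with a range from 30000 nM to 220000 nM. This expectation amounts to a 1.0-fold higher number from compound 3 to compound 4 (0.01 log units; within the scatter).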

Compound 4, half-maximal cytotoxic concentration: 160000 nM
Beside the measured number, compound 4's estimate is 2.0-fold (0.30 log units) below it, within the range that was stated.
By their numbers in this assay, from the lowest: compound 1; then compound 3; then compound 4. At a limit, above all of these: compound 2.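

The acyl end of this ester side chain is not indifferent in this assay: with only carbon atoms changing, the swap gives a 2.1-fold higher number from compound 3 to compound 4 (0.31 log units; beyond the scatter), a modest move toward lower toxicity in this test. So a shift beyond the usual scatter at this position does not require adding or removing any hydrogen-bond donor or acceptor, and the earlier compounds, which offered no step at this position, could not show that. No measured property shown here accounts for this step.

The change adds a ring and one more carbon together, so these two compounds cannot tell which of the two matters. Also open, from the compounds shown here alone, is how this position would respond to a phenyl ring, a longer chain, or a chain ending in an amine or a carboxylic acid.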